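The source may report more compounds than this note shows. Statements on the series, on what has been measured and on what is new or still open speak of the compounds shown alone.

Measured so far:
compound 1 `Cc1ccccc1-n1nc(C)c2c1NC(=O)[C@H](C)S[C@@H]2c1ccc(Oc2ccccc2)cc1` — 1300 nM
compound 2 `Cc1nn(-c2ccccc2Cl)c2c1C(c1ccc(Oc3ccccc3)cc1)SC(C)C(=O)N2` — 2700 nM

In an assay on isolated protein for agonist activity at Bile acid receptor (Homo sapiens), read by AlphaScreen, with a stated time of 30 min (on this read-out higher numbers stand for an effect only at larger amounts of compound and lower numbers for an effect already at smaller amounts), compound 1 gives 1300 nM, the lowest of the two numbers; compound 2 gives 2700 nM, a number that sits beyond the scatter above it. For the measured compounds named here, no pair of measured compounds differs in a single place, so no measured step is available to lean on. Compound 3 `Cc1ccccc1-n1nc(C)c2c1NC(=O)[C@H](C)S[C@@H]2c1ccc(OCc2ccccc2)cc1` differs from compound 1 by benzyl in place of phenyl on an oxygen on an aromatic ring. Nothing measured shows what this change does in the series. The step of a 1.2-fold higher number from compound 1 to compound 3 (0.09 log units; within the scatter) is expected to stay within the scatter, leaning if anything toward a higher number. Compound 3 is estimated at 1600 nM, in the range 450 nM to 5500 nM.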

Compound 3, half-maximal effective concentration: "not active" (no number reported)
No number was reported for compound 3; no gap can be computed for the estimate.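

For the compounds shown here, compound 3 is reported as not active, with no number, and no step from compound 1 to compound 3 can be read. The compounds shown leave open what phenoxy to benzyloxy does in this series. No measured evidence bears on this result.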